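This account rests on a few compounds, and the source may have more. Where it says the series, first, only, none or still open, it means among the compounds named here.

Compound 1 `Clc1ccc(-c2cc(-c3ccco3)cc(-c3ccc(Cl)s3)n2)cc1`: 14800 nM
Compound 2 `Cc1ccc(-c2cc(-c3ccoc3)cc(-c3ccc(Cl)s3)n2)cc1`: 25300 nM

Within the data shown here, in a functional assay on DU-145 cells (Homo sapiens) for cytotoxicity, read by ELISA, with a stated time of 4 days (on this read-out lower numbers stand for stronger inhibition and higher numbers for weaker inhibition), compound 2 gives 25300 nM and compound 1 gives 14800 nM, so compound 2 stands within the usual scatter of the only other measured compound. Compound 3 `Clc1ccc(-c2cc(-c3ccoc3)cc(-c3cccnc3)n2)s1` carries pyridin-3-yl in place of 4-methylphenyl on an aromatic carbon. Among the measured compounds shown here, no measured pair shows this change. The expected step in this assay, a 1.0-fold lower number from compound 2 to compound 3 (0.01 log units; within the scatter), is none beyond the scatter. For compound 3 the estimated value is 25000 nM, with an expected range of 10000 nM to 60000 nM.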

Compound 3, half-maximal inhibitory concentration: 18500 nM
Compound 3: the middle estimate sits 1.4-fold (0.13 log units) above what was measured; the range from low to high includes it.
By their numbers in this assay, from the lowest: compounds 1, 3 and 2 (each within the scatter of the next).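

In this assay, pyridin-3-yl in place of 4-methylphenyl, on an aromatic carbon next to the ring nitrogen, gives a 1.4-fold lower number from compound 2 to compound 3 (0.14 log units; within the scatter) and so does not separate the two compounds. Among these compounds, this is the first comparison at this position: a ring with a hetero atom and a hydrogen-bond acceptor replaces a ring of carbon only, with no change beyond the scatter. No supporting evidence is available to explain this result.

The compounds shown leave open whether an amine or a carboxylic acid at this position would shift the number beyond the scatter. They also do not show whether pyridin-4-yl would behave like pyridin-3-yl.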